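The source may hold more compounds than are shown below. What is called first, only, known or untested is meant among the compounds shown, and "the series" means these compounds.

Compound 1 `CC(=N)NCCC(O)c1ccccc1N`: 16.2% in an assay for inhibition of Nitric oxide synthase, inducible (Homo sapiens), with a stated time of 30 min, tested at 1 mM; a higher number here means more inhibition at the concentration tested (going by the name of the read-out), a lower number less inhibition
Compound 2 `N=C(NCCC(O)c1ccccc1N)c1ccccc1`: 64.1% in this assay
Compound 3 `CC(=N)NCCC(O)c1cc(Cl)ccc1N`: 49.1% in this assay

Compound 3 holds the second highest of these three numbers. It sits above compound 1 by a number 32.9 percentage points higher from compound 1 to compound 3 (beyond the scatter), a large step that came with chloro in place of hydrogen on an aromatic carbon, and its value lies below that of compound 2, which is the highest of the three. The other measured step, a number 47.9 percentage points higher from compound 1 to compound 2 (beyond the scatter), concerns phenyl in place of methyl on a carbon with a double bond to nitrogen, a different part of the shared core, and does not bear on the change at hand.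

Compound 4 `COc1ccc(N)c(C(O)CCNC(C)=N)c1` differs from compound 3 in one place: methoxy in place of chloro on an aromatic carbon. Going by the values given here, no measured pair shows methoxy against chloro, or methoxy against hydrogen, at that aromatic carbon, so the direction of the step rests only on the chloro step. Because the chloro gave the large rise seen in a number 32.9 percentage points higher from compound 1 to compound 3 (beyond the scatter), its removal is expected to cost part of that gain, with the entering methoxy of uncertain weight. A fall of a number 17.1 percentage points lower from compound 3 to compound 4 (beyond the scatter) is therefore expected, beyond the scatter but short of the value of compound 1. For compound 4 the expected result in this assay is 32%, in a range from 12% to 55%.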

Compound 4, a percentage reported as inhibition, at one concentration (the size of the read-out at that concentration, not a potency): 57.4%
The estimate for compound 4 lay 25.4 percentage points below the measured number; the measured number lies above the stated range.
By their numbers in this assay, from the lowest: compound 1; then compounds 3, 4 and 2 (each within the scatter of the next, the first and the last beyond it).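

In this assay, the exchange of chloro for methoxy on the aromatic carbon para to an amino group leaves the two groups indistinguishable (the step reads a number 8.3 percentage points higher from compound 3 to compound 4 (within the scatter)), although they differ in heavy atoms and in hydrogen-bond acceptors. Against hydrogen at the same carbon, methoxy gives a large step (a number 41.2 percentage points higher from compound 1 to compound 4 (beyond the scatter)), so the rise seen earlier with chloro (a number 32.9 percentage points higher from compound 1 to compound 3 (beyond the scatter)) is no longer tied to a single group, and both groups shown at this carbon stand beyond the scatter above hydrogen, with no compound here going against that. Nothing measured here accounts for this rise or says what chloro and methoxy share at this position.

Going by these compounds, whether the rise extends to other groups at this carbon, such as fluoro, a hydroxyl, an amine or a carboxylic acid, remains open, since two groups cannot define a trend. Also open, on these data alone, is whether methoxy at this carbon would add to phenyl in place of methyl on the carbon with a double bond to nitrogen, or whether the two changes would overlap in this read-out.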